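Pyrrolidinone oxadiazoles: exchanging the aryl on the lactam nitrogen

The source may report more compounds than this note shows. Statements on the series, on what has been measured and on what is new or still open speak of the compounds shown alone.

Compound 1 `O=C1CC(c2nc(-c3cccc(Cl)c3)no2)CN1c1ccccc1Cl` is measured in an in vitro functional assay on HEK293-A cells for positive allosteric modulation of metabotropic glutamate receptor 5 (Homo sapiens), read by FLIPR and calcium flux (a higher number here means that more compound is needed for the effect, a lower number that less compound is needed), and gives only a limit, > 10000 nM, so no number is known for it. Compound 3 `Cc1cccc(-c2noc(C3CC(=O)N(c4ccc(Cl)cc4)C3)n2)n1` also sits at a limit in this assay, > 10000 nM. Both therefore rest at the limit of > 10000 nM in this assay, at which 2 of the 3 values shown sit. Among the compounds with values here, compound 2 `O=C1CC(c2nc(-c3ccccc3)no2)CN1c1ccc(F)cc1` is the one member of the set with a number, giving 58 nM in this assay. Within the data shown here, compound 1 thus stands at the weak end of what has been measured, as far as a limit allows any placing; no single-point step from compound 1 to any measured compound is available, so the gap to compound 2 shows only that the two values differ by more than the scatter.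

Compound 4 `COc1cccc(N2CC(c3nc(-c4cccc(Cl)c4)no3)CC2=O)c1` is not yet measured. It differs from compound 1 by 3-methoxyphenyl in place of 2-chlorophenyl on an amide-type nitrogen in a ring. Nothing measured isolates this exchange, so the size of the step from compound 1 to compound 4 is an open guess. In this assay compound 4 is estimated at 2000 nM, with a range from 300 nM to 10000 nM. The step of an at least 5.0-fold lower number from compound 1 to compound 4 (0.69 log units; beyond the scatter) is expected to run toward a lower number, that is, toward less compound needed, but a second limit is a real possibility.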

Compound 4, half-maximal effective concentration: > 10000 nM
Compound 4 was reported as a limit; the forecaster's own chance of this, stated with the estimate: 35%; middle value at least 5.0-fold (0.69 log units) away from the limit.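

Within the data shown here, compound 4 is reported only as a limit, as is compound 1, and no step between compound 1 and compound 4 can be read. The compounds shown leave open whether 3-methoxyphenyl in place of 2-chlorophenyl on the amide-type nitrogen changes the value at all, and how far either compound lies from the limit.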